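Lengthening a Methyl to an Ethyl on a Bromo Compound

The source may hold more compounds than are shown below. What is called first, only, known or untested is meant among the compounds shown, and "the series" means these compounds.

So far three compounds have been tested in a functional assay on DU-145 cells (Homo sapiens) for antiproliferative activity, read by MTT assay, with a stated time of 48 h; a higher number here means a weaker inhibitor, a lower number a stronger inhibitor. Compound 1 `CCN1C(=O)C(O)(Cc2nnn[nH]2)c2ccccc21` reaches only a limit, > 100000 nM. Compound 2 `CCN1C(=O)C(O)(Cc2nnn[nH]2)c2cc(Cl)ccc21` gives a true number, 21500 nM. Compound 3 `CN1C(=O)C(O)(Cc2nnn[nH]2)c2cc(Br)ccc21` also reaches only a limit, > 100000 nM, and so stands at the limit of > 100000 nM in this assay, at which 2 of the 3 values shown sit.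

Compound 4 `CCN1C(=O)C(O)(Cc2nnn[nH]2)c2cc(Br)ccc21` follows from compound 3 by one change, methyl in place of hydrogen on a saturated chain carbon bound to an amide-type nitrogen in a ring, or methyl to ethyl when cut one bond further out. Within the data shown here, no measured step tests this change directly. Among the measured compounds shown here, the only measured step is an at least 4.6-fold lower number from compound 1 to compound 2 (0.66 log units; beyond the scatter), with chloro in place of hydrogen on an aromatic carbon. It bears only indirectly, by showing that compound 2, an ethyl compound with a halogen on the aromatic ring, registers a number in this assay. Compound 3 goes against any broader reading, since it also has a halogen there yet gives no number.

A modest move towards a lower number is therefore expected, and another limit remains quite possible. The expected change is an at least 2.5-fold lower number from compound 3 to compound 4 (0.39 log units; beyond the scatter). For compound 4 the estimate is 40000 nM, with an expected range from 12000 nM to 100000 nM.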

Compound 4, half-maximal inhibitory concentration: > 100000 nM
Compound 4: a limit, no number; the forecaster's own chance of this, stated with the estimate: 40%; middle value at least 2.5-fold (0.39 log units) from the limit.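

Lengthening methyl to ethyl at this position does not bring the bromo compound to a true number in this assay: compound 3 and compound 4 both end as limits, so the steps from compound 3 and from compound 1 to compound 4 cannot be read. Among these compounds, the one readable step lies on the aromatic carbon, not on the chain, and with ethyl held on the amide-type nitrogen in a ring, bromo in place of chloro gives an at least 4.6-fold higher number from compound 2 to compound 4 (0.66 log units; beyond the scatter). The earlier hint that an ethyl compound with a halogen on the aromatic carbon registers a number therefore holds for compound 2 alone, and compound 4 goes against it, leaving most of this small set at one value: the limit of > 100000 nM in this assay, at which 3 of the 4 values shown sit.

The compounds shown leave open whether compound 3 and compound 4 differ at all, and whether a methyl compound with chloro on the aromatic carbon would also give a number. They also leave open how a longer chain such as propyl on that nitrogen, or an amine or a carboxylic acid on the aromatic carbon, would read.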